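A Methyl Group Removed From the Fluorophenyl Tail

The compounds below may be only part of what the source reports. "The series", "measured", "known", "first", "only" and "open" are said of these compounds alone.

compound 1 `C=C/C=C\[C@H](C)[C@H](OC(N)=O)[C@@H](C)[C@H](O)[C@@H](C)C/C(C)=C\[C@H](C)[C@@H](O)[C@@H](C)/C=C\CCc1ccc(Oc2ccccc2)cc1` gives 10000 nM
compound 2 `C=C/C=C\[C@H](C)[C@H](OC(N)=O)[C@@H](C)[C@H](O)[C@@H](C)C/C(C)=C\[C@H](C)[C@@H](O)[C@@H](C)/C=C\CCc1ccc(C)c(F)c1` gives 1000 nM

In a functional assay on SK-OV-3 cells (Homo sapiens) for cytotoxicity (on this read-out higher numbers stand for weaker inhibition and lower numbers for stronger inhibition), compound 2 has the lower of the two numbers (1000 nM) and compound 1 the higher (10000 nM), a gap beyond the usual scatter. Compound 3 `C=C/C=C\[C@H](C)[C@H](OC(N)=O)[C@@H](C)[C@H](O)[C@@H](C)C/C(C)=C\[C@H](C)[C@@H](O)[C@@H](C)/C=C\CCc1cccc(F)c1` has not yet been measured. It departs from compound 2 in one place (hydrogen in place of methyl on an aromatic carbon), with hydrogen in place of methyl on an aromatic carbon, so that 3-fluoro-4-methylphenyl becomes 3-fluorophenyl. Within the data shown here, no measured pair shows this change on its own, so the expectation rests on compound 2 (1000 nM) as the nearest measured structure. In this assay a step beyond the scatter is not expected, and no firm direction can be given: the estimated 1.2-fold higher number from compound 2 to compound 3 (0.08 log units; within the scatter) is small. Compound 3 is estimated at 1200 nM (expected range 350 nM to 4000 nM).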

Compound 3, half-maximal inhibitory concentration: 400 nM
Estimate against measurement, compound 3: 3.0-fold (0.48 log units) above; the measured number falls inside the stated range.
By their numbers in this assay, from the lowest: compound 3; then compound 2; then compound 1.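

In this assay, among these compounds, taking the methyl group off the aromatic carbon ortho to the fluoro group, so that 3-fluoro-4-methylphenyl becomes 3-fluorophenyl, brings a 2.5-fold lower number from compound 2 to compound 3 (0.40 log units; beyond the scatter) and gives the first single-place comparison. The step is modest but beyond the scatter, and it shows that this methyl group is not needed for inhibition in this pair: hydrogen at this position gives the stronger inhibition. No measurement shown accounts for the shift, so its cause remains unknown.

The compounds shown leave open whether a chlorine atom, a methoxy group or an amine at this position would move the number further, or whether hydrogen is preferred among such groups. They also leave open what happens when the fluoro group gives way to hydrogen, leaving an unsubstituted phenyl ring on the same chain.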